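The compounds below may be only part of what the source reports. "The series", "measured", "known", "first", "only" and "open" are said of these compounds alone.

Among the compounds with values here, compound 2, with the structure `CCCCCSc1n[nH]c(-n2[se]c3ccccc3c2=O)n1`, holds the lower of the two numbers measured so far in a functional assay on SMMC-7721 cells (Homo sapiens) for antiproliferative activity, read by CCK-8 assay, with a stated time of 48 h (a lower number here means a stronger inhibitor, a higher number a weaker inhibitor), giving 31400 nM. Within the data shown here, its only measured companion is compound 1, whose structure is `O=c1c2ccccc2[se]n1-c1nc(SCc2ccc(F)cc2)n[nH]1` and which gives 46100 nM. The step between them, a 1.5-fold lower number from compound 1 to compound 2 (0.17 log units; within the scatter), is small enough to fall within the scatter of repeated measurements, so the two compounds cannot be told apart on these numbers.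

Compound 3, with the structure `CCSc1n[nH]c(-n2[se]c3ccccc3c2=O)n1`, differs from compound 2 in one place: hydrogen in place of propyl on a saturated chain carbon, two bonds along the chain from a sulfur. Among the measured compounds shown here, the single measured step, a 1.5-fold lower number from compound 1 to compound 2 (0.17 log units; within the scatter), bears on this change only loosely, since it exchanged one group for another on the carbon bound to the sulfur, whereas here the chain on that side of the sulfur is simply cut shorter. That one step stayed within the scatter, and nothing measured points to a particular direction for a shortening of the chain.

The estimate for compound 3 is therefore a number close to that of compound 2, at 35000 nM with a range from 14000 nM to 85000 nM, which means an expected step of a 1.1-fold higher number from compound 2 to compound 3 (0.05 log units; within the scatter).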

Compound 3, half-maximal inhibitory concentration: 10000 nM
Beside the measured number, compound 3's estimate is 3.5-fold (0.54 log units) above it, and the stated range ends above it.
By their numbers in this assay, from the lowest: compound 3; then compounds 2 and 1 (each within the scatter of the next).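

Shortening the pentyl chain on the sulfur to ethyl is the first change in this assay that clears the scatter: it gives a 3.1-fold lower number from compound 2 to compound 3 (0.50 log units; beyond the scatter). The earlier exchange at this end of the molecule, butyl in place of 4-fluorophenyl, could not be told apart from repeat-to-repeat variation, so this position had shown no clear response until now. Methyl in place of 4-fluorophenyl on the saturated chain carbon bound to the sulfur gives a 4.6-fold lower number from compound 1 to compound 3 (0.66 log units; beyond the scatter), so compound 3 stands apart from both earlier compounds, although both steps are modest and no available evidence explains the difference.

As far as these compounds go, with only ethyl and pentyl as plain chains on the sulfur, it remains open whether the number changes gradually with chain length or shifts abruptly, and a propyl or butyl chain would help to separate these two possibilities. From the compounds shown here alone, it is also open whether a still smaller methyl on the sulfur would go further in the same direction, and how a hydroxyl or an amine at the end of the ethyl chain would change the number.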